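A few compounds are considered here, and "the series" means these few. Any claim that something is new, unique, unknown or untested is made for them only; others in the source may bear on it.

Compound 1 `CSc1nc2cc(Cl)c(Cl)cc2n1[C@@H]1O[C@H](CO)[C@@H](O)[C@H]1O` carries a methylsulfanyl group on the shared core. In a functional assay on KB cells (Homo sapiens) for inhibition (a higher number here means a weaker inhibitor, a lower number a stronger inhibitor), compound 1 gives only a limit of the assay, > 100000 nM. Compound 2 `CSc1nc2cc(Cl)c(Cl)cc2n1[C@@H]1O[C@@H](CO)[C@@H](O)[C@H]1O` has the same atoms and bonds and differs only in the configuration drawn at one saturated ring carbon. In this assay compound 2 likewise gives only a limit, > 100000 nM. The step that the two limits leave unreadable from compound 1 to compound 2 cannot be read because of the limit of > 100000 nM in this assay, at which 2 of the 2 values shown sit, and it tells nothing about the size or direction of any change, even though (the fact that compounds 1 and 2 differ only in the configuration as drawn).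

Compound 3 `OC[C@H]1O[C@@H](n2c(S)nc3cc(Cl)c(Cl)cc32)[C@H](O)[C@@H]1O` is reached from compound 1 by hydrogen in place of methyl on a sulfur, methylsulfanyl becoming sulfanyl. For the measured compounds named here, no measured step bears on this change, so the only anchor is that compound 1 sits at the limit. Compound 3 is therefore expected to stand near that limit, estimated at 100000 nM, with a range from 20000 nM to 500000 nM. The expected step is a number no higher from compound 1 to compound 3 (the limit leaves the size open), with no direction claimed.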

Compound 3, half-maximal inhibitory concentration: > 100000 nM
Compound 3: only a limit was reported; the forecaster's own chance of this, stated with the estimate: 80%; the middle value lies on the limit itself.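

In this assay compound 3 also gives only a limit of the assay, > 100000 nM, so the step to it from compound 1 cannot be read: the limit of > 100000 nM in this assay, at which 3 of the 3 values shown sit.

The compounds shown leave open whether changing the group on the sulfur or the configuration at the saturated ring carbon alters inhibition at all.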